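The compounds below may be only part of what the source reports. "The series", "measured", "known", "first", "only" and "open" are said of these compounds alone.

Compound 2 `COc1cc(-c2nn(-c3cccc(NC(=O)Nc4cc(C(F)(F)F)cc(C(F)(F)F)c4)c3)cc2-c2ccncc2)ccc1Cl` gives the highest of the two numbers that were actually read in a functional assay on RXF 393 cells (Homo sapiens) for inhibition, read by sulforhodamine B assay, with a stated time of 48 h (on this read-out lower numbers stand for higher toxicity in this test and higher numbers for lower toxicity in this test), namely 4900 nM, with compound 3 `COc1cc(-c2nn(-c3cccc(NC(=O)Nc4cccc(C(F)(F)F)c4)c3)cc2-c2ccncc2)ccc1Cl` next at 4830 nM. Compound 1 `O=C(Nc1cccc(-n2cc(-c3ccncc3)c(-c3ccc(Cl)c(O)c3)n2)c1)Nc1cccc(C(F)(F)F)c1` sits at the limit of this assay, > 32500 nM. The step to compound 4 `O=C(Nc1cccc(-n2cc(-c3ccncc3)c(-c3ccc(Cl)c(O)c3)n2)c1)Nc1cc(C(F)(F)F)cc(C(F)(F)F)c1` is hydrogen in place of methyl on an oxygen on an aromatic ring.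

Going by the values given here, two measured steps bear on it. Among the compounds with values here, the first, an at least 6.7-fold lower number from compound 1 to compound 3 (0.82 log units; beyond the scatter), is the same change run the other way, and it is the one comparison that speaks directly: it reached the limit, as the limit of > 32500 nM in this assay, at which 1 of the 3 values shown sits, records. The second, a 1.0-fold lower number from compound 2 to compound 3 (0.01 log units; within the scatter), shows that the pair of trifluoromethyl groups on the outer ring of compound 2 makes no difference beyond the scatter, so the urea end of compound 2 is not expected to alter what the first step showed.

Compound 4 is therefore expected to move in the opposite direction to the first step, by a 6.7-fold higher number from compound 2 to compound 4 (0.83 log units; beyond the scatter), with a real chance that this assay again reports only a limit. The estimate for compound 4 is 33000 nM, with a range from 15000 nM to 100000 nM.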

Compound 4, concentration lethal to 50% of the cells: 10700 nM
Beside the measured number, compound 4's estimate is 3.1-fold (0.49 log units) above it, and the stated range ends above it.
By their numbers in this assay, from the lowest: compounds 3 and 2 (each within the scatter of the next); then compound 4. At a limit, above all of these: compound 1.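

In this assay, hydrogen in place of methyl on this oxygen raises the number on a second core as well, a 2.2-fold higher number from compound 2 to compound 4 (0.34 log units; beyond the scatter), so the direction seen in the earlier pair holds, but the size of the step depends on the core: the same change on two cores in this assay, an at least 6.7-fold lower number (0.82 log units; beyond the scatter) from compound 1 to compound 3 and a 2.2-fold lower number (0.34 log units; beyond the scatter) from compound 4 to compound 2, at least 3.0-fold (0.48 log units) apart, beyond the scatter of two such steps
The trifluoromethyl group that compound 4 carries beyond compound 1 also counts among the hydroxy compounds, an at least 3.0-fold lower number from compound 1 to compound 4 (0.48 log units; beyond the scatter), although the same difference was silent among the methoxy compounds: the same change on two cores in this assay, a 1.0-fold lower number (0.01 log units; within the scatter) from compound 2 to compound 3 and an at least 3.0-fold higher number (0.48 log units; beyond the scatter) from compound 4 to compound 1, at least 3.0-fold (0.48 log units) apart, beyond the scatter of two such steps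
Methoxy to hydroxy and the number of trifluoromethyl groups on the outer ring therefore do not add up independently on this read-out, and compound 1, at > 32500 nM, is a limit of this assay and not a number, so the gaps that rest on it are minimum sizes only.

From the compounds shown here alone, whether a longer chain on this oxygen, such as ethyl, would read like the methoxy compounds or the hydroxy compounds stays open. So does whether an amine in place of the hydroxy would keep the higher numbers, and whether the dependence on the outer ring would persist with a group other than trifluoromethyl there, such as a nitrile.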